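This account rests on a few compounds, and the source may have more. Where it says the series, first, only, none or still open, it means among the compounds named here.

Measured so far in an assay on isolated protein for inhibition of Aromatase (Homo sapiens), read by ELISA, using NADPH, with a stated time of 24 h; on this read-out higher numbers stand for weaker inhibition and lower numbers for stronger inhibition:

compound 1, `Fc1ccc(-c2[nH]c3cc(F)ccc3c2Cn2ccnc2)cc1`: 51.2 nM
compound 2, `Fc1ccc2c(Cn3ccnc3)c(-c3ccc(Cl)cc3)[nH]c2c1`: 82.9 nM
compound 3, `COc1ccc2c(Cn3cncn3)c(-c3ccc(F)cc3)[nH]c2c1`: 238 nM

Compound 2 differs from compound 1 in one place, (chloro in place of fluoro on an aromatic carbon). In this assay the step from compound 1 to compound 2 is a 1.6-fold higher number from compound 1 to compound 2 (0.21 log units; within the scatter), so on this pair the exchange of halogen leaves the read-out essentially where it was.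

Compound 3 carries a different core; the difference between the core of compound 1 and the core of compound 3 is not broken down here. Its number in this assay is the highest of the three, and its distance to compound 2 and to compound 1 is in both cases beyond the usual scatter, so compound 3 reads as the weaker inhibitor of the measured set.

Compound 4, `COc1ccc2c(Cn3cncn3)c(-c3ccc(Cl)cc3)[nH]c2c1`, is not yet measured. It stands to compound 3 as compound 2 stands to compound 1: the difference is chloro in place of fluoro on an aromatic carbon, at the same place on the same kind of ring, so this is the same change made on the other core.

For compound 4 the expected step in this assay is a 1.5-fold higher number from compound 3 to compound 4 (0.18 log units; within the scatter), which rests on the earlier step of a 1.6-fold higher number from compound 1 to compound 2 (0.21 log units; within the scatter) measured on the related pair. Compound 4 is therefore estimated at 360 nM in this assay. For compound 4 the expected range runs from 180 nM to 720 nM.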

Compound 4, half-maximal inhibitory concentration: 7770 nM
Beside the measured number, compound 4's estimate is 22-fold (1.33 log units) below it; the measured number lies above the stated range.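

In this assay, for the compounds shown here, the exchange of 4-fluorophenyl for 4-chlorophenyl on the second core gives a 33-fold higher number from compound 3 to compound 4 (1.51 log units; beyond the scatter), a large loss of inhibition where the first core showed no change beyond the scatter. The exchange therefore does not carry over between these two cores at a constant size, and the step read on one core is no guide to the step on the other: the same change on two cores in this assay, a 1.6-fold higher number (0.21 log units; within the scatter) from compound 1 to compound 2 and a 33-fold higher number (1.51 log units; beyond the scatter) from compound 3 to compound 4, 20-fold (1.30 log units) apart, beyond the scatter of two such steps This does not show which part of the cores sets the gap: they differ in more than one place, no pair shown separates those places, and two pairs give no rule for any further core.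

Open, on these data alone, is which of the differing places in the core governs the response to the halogen, a question that needs fluoro and chloro pairs on cores differing from one another in one place only. Also open, as far as these compounds go, is whether bromo, methyl or nitrile on the same aromatic carbon would track the chloro or the fluoro on each core, and so whether the large step is specific to chloro or extends to other replacements of fluoro.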